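A Chloro for Methyl Swap on Compound 1

The source may report more compounds than this note shows. Statements on the series, on what has been measured and on what is new or still open speak of the compounds shown alone.

compound 1 `Cc1ccc(C(=O)c2cc(F)c(OCC(=O)NNC(=O)c3ccc(=O)oc3)c(Cl)c2)cc1`: 23600 nM
compound 2 `Cc1ccc(C(=O)c2cc(F)c(OCC(=O)NNC(=O)c3cn(C)cn3)c(Cl)c2)cc1`: 9800 nM

In a functional assay on MCF7 cells (Homo sapiens) for cytotoxicity, read by MTT assay, with a stated time of 48 h (a higher number here means a weaker inhibitor, a lower number a stronger inhibitor), compound 1 gives 23600 nM, the highest of the two numbers shown. Within the data shown here, the only measured step reads a 2.4-fold lower number from compound 1 to compound 2 (0.38 log units; beyond the scatter), a modest change at the carbonyl end of the shared core. Compound 3 `O=C(COc1c(F)cc(C(=O)c2ccc(Cl)cc2)cc1Cl)NNC(=O)c1ccc(=O)oc1` differs from compound 1 by chloro in place of methyl on an aromatic carbon. No measured step touches that position, so nothing shown bears on this change. A step within the scatter is therefore expected. Compound 3 is estimated at 20000 nM, with a range of 8000 nM to 50000 nM. That estimate implies a 1.2-fold lower number from compound 1 to compound 3 (0.07 log units; within the scatter), expected to stay inside the scatter.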

Compound 3, half-maximal inhibitory concentration: 86200 nM
Compound 3: middle estimate off by 4.3-fold (0.63 log units), on the low side; the measured number lies above the stated range.
By their numbers in this assay, from the lowest: compound 2; then compound 1; then compound 3.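

Among these compounds, compound 1 and compound 3 give the first reading of this position, on an aromatic carbon para to a large group. In this assay the swap of methyl for chloro gives a 3.7-fold higher number from compound 1 to compound 3 (0.56 log units; beyond the scatter), so exchanging this one heavy atom moves the number beyond the scatter. The compounds shown offer no measured reason for this step.

As far as these compounds go, whether a methoxy group or an amine here would read closer to methyl or to chloro stays open. Also open, from the compounds shown here alone, is whether the same swap would move compound 2 in the same direction.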